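This account rests on a few compounds, and the source may have more. Where it says the series, first, only, none or still open, it means among the compounds named here.

Compounds measured in an assay on lysate for inhibition of phosphatidylcholine:ceramide cholinephosphotransferase 2 (Homo sapiens), read by HPLC, with stated times of 30 min and 2 h; a lower number here means a stronger inhibitor, a higher number a weaker inhibitor:
- compound 1, `O=C(Nc1cccnc1)c1ccccc1OCc1ccccc1`: 3200 nM
- compound 2, `N#Cc1ccccc1COc1ccccc1C(=O)Nc1cccnc1`: 31800 nM
- compound 3, `O=C(Nc1cccnc1)c1ccccc1OCc1cc(F)ccc1Cl`: 740 nM

Compound 3 stands at the lowest number of the three; its nearest neighbour is compound 1, as the step of a 4.3-fold lower number from compound 1 to compound 3 (0.64 log units; beyond the scatter) shows, and compound 2 lies furthest away, as the step of a 43-fold lower number from compound 2 to compound 3 (1.63 log units; beyond the scatter) shows. The unmeasured compound 4, `Cc1c(Cl)cccc1COc1ccccc1C(=O)Nc1cccnc1`, differs from compound 3 only at the group on the saturated chain carbon bound to an oxygen on the aromatic ring: 3-chloro-2-methylphenyl in place of 2-chloro-5-fluorophenyl on a saturated chain carbon bound to an oxygen on an aromatic ring. Both measured steps into compound 3 bear on this change, since each alters the same group: a 4.3-fold lower number from compound 1 to compound 3 (0.64 log units; beyond the scatter) and a 43-fold lower number from compound 2 to compound 3 (1.63 log units; beyond the scatter). Both show that this group moves the number well beyond the scatter, and that a chlorine-bearing ring gave the lowest number seen. Compound 4 keeps a chlorine on that ring but shifts it and exchanges fluorine for methyl, so a smaller step than either measured one is expected in this assay, and compound 4 is estimated at 1100 nM, within 400 nM to 3200 nM, which means an expected step of a 1.5-fold higher number from compound 3 to compound 4 (0.17 log units; within the scatter).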

Compound 4, half-maximal inhibitory concentration: 3800 nM
Compound 4: middle estimate off by 3.5-fold (0.54 log units), on the low side; measured number above the stated range.
By their numbers in this assay, from the lowest: compound 3; then compounds 1 and 4 (each within the scatter of the next); then compound 2.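

In this assay a chlorine on this ring did not on its own keep the number low, as a 5.1-fold higher number from compound 3 to compound 4 (0.71 log units; beyond the scatter) shows for two rings that both carry one on a saturated chain carbon bound to an oxygen on an aromatic ring. The 3-chloro-2-methylphenyl group also gives no separation from plain phenyl, with a 1.2-fold higher number from compound 1 to compound 4 (0.07 log units; within the scatter) here, although an 8.4-fold lower number from compound 2 to compound 4 (0.92 log units; beyond the scatter) keeps it clear of 2-cyanophenyl, so compound 3 alone among the chlorine-bearing pair goes with the lowest number. No measurement offered here accounts for the gap between these two rings.

The compounds shown leave open how much of the step belongs to the chlorine and how much to the fluorine of 2-chloro-5-fluorophenyl. On these data alone, how a ring bearing a methoxy group or an amine would read at this place also stays open.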